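The compounds below may be only part of what the source reports. "The series", "measured", "known", "first", "only" and "open" are said of these compounds alone.

Measured compounds in a functional assay on Jurkat cells for inhibition of nuclear factor NF-kappa-B complex (Homo sapiens); a higher number here means a weaker inhibitor, a lower number a stronger inhibitor:
Compound 1 `CCOC(=O)c1cnc(C(F)(F)F)nc1NN1C(=O)C=C(C)C1=O` gives 1000 nM.
Compound 2 `CCOC(=O)c1cnc(SC)nc1NN1C(=O)C=C(C)C1=O` gives 200 nM.
Compound 3 `CCOC(=O)c1cnc(-c2csc(C)n2)nc1NN1C(=O)C=C(C)C1=O` gives 8000 nM.

Compound 3 has the highest number of the three and is the weakest inhibitor here: an 8.0-fold higher number from compound 1 to compound 3 (0.90 log units; beyond the scatter), and a 40-fold higher number from compound 2 to compound 3 (1.60 log units; beyond the scatter). Compound 4 `CCOC(=O)c1cnc(-c2cccc(Br)c2)nc1NN1C(=O)C=C(C)C1=O` differs from it in one place: 3-bromophenyl in place of 2-methyl-1,3-thiazol-4-yl on an aromatic carbon. For the measured compounds named here, no measured step swaps one aromatic ring for another; the two steps that bear on this position only show that putting an aromatic ring there gave a higher number than either smaller group, the change from compound 2 being the larger. Compound 4 keeps an aromatic ring in that place, so the number is expected to stay close. The expected step is no change at the digits printed from compound 3 to compound 4 (within the scatter), within the scatter. Compound 4 is estimated at 8000 nM, with a range from 2000 nM to 30000 nM.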

Compound 4, half-maximal inhibitory concentration: 700 nM
The estimate for compound 4 lay 11-fold (1.06 log units) above the measured number, outside the stated range (below it).
By their numbers in this assay, from the lowest: compound 2; then compounds 4 and 1 (each within the scatter of the next); then compound 3.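

In this assay, an aromatic ring at this position does not by itself give a high number: swapping the ring alone produces an 11-fold lower number from compound 3 to compound 4 (1.06 log units; beyond the scatter) so the kind of ring matters. The 3-bromophenyl group still gives a weaker result than methylsulfanyl, with a 3.5-fold higher number from compound 2 to compound 4 (0.54 log units; beyond the scatter) while a 1.4-fold lower number from compound 1 to compound 4 (0.15 log units; within the scatter) stays within the scatter, so 3-bromophenyl and trifluoromethyl cannot be told apart here. No measurement shown explains the difference between the two rings.

Still open, on these data alone, is whether the bromine contributes, which a plain phenyl group would test, and how an amine or ethylsulfanyl group would compare at this position.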